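The compounds below may be only part of what the source reports. "The series", "measured", "known", "first", "only" and "open" are said of these compounds alone.

Compound 1 `O=C(CCCCCCc1ccccc1F)N1CCCC1` gives 13700 nM in an assay on HEK293 cells for inhibition of N-acylethanolamine-hydrolyzing acid amidase (Rattus norvegicus), read by LC-MS, with a stated time of 30 min; on this read-out lower numbers stand for stronger inhibition and higher numbers for weaker inhibition.
Compound 2 `O=C(CCCCCCc1cccc(F)c1)N1CCCC1` gives 7300 nM in this assay.
Compound 3 `Cc1ccc(-c2ccc(CCC(=O)N3CCCC3)cc2)cc1` gives 33200 nM in this assay.

Among the three, compound 2 carries the lowest number, but compound 1 lies within the usual scatter of it, so the two cannot be separated; compound 3 sits beyond the scatter, at a higher number. Compound 4 `O=C(O)c1cccc(CCCCCCC(=O)N2CCCC2)c1` has not yet been measured. It differs from compound 2 by carboxy in place of fluoro on an aromatic carbon. Among the measured compounds shown here, no measured pair in this set isolates such an exchange, so the outlook rests on expectation alone. A moderate rise in the number is expected, a 2.2-fold higher number from compound 2 to compound 4 (0.34 log units; beyond the scatter), beyond the scatter but not far. Compound 4 is accordingly estimated at 16000 nM, with a range from 4500 nM to 60000 nM.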

Compound 4, half-maximal inhibitory concentration: > 100000 nM
Compound 4 gave a limit, no number; the forecaster's own chance of this, stated with the estimate: 20%; middle value at least 6.2-fold (0.79 log units) from the limit.
By their numbers in this assay, from the lowest: compounds 2 and 1 (each within the scatter of the next); then compound 3. At a limit, above all of these: compound 4.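

Compound 4 gives only a limit, not a number, in this assay: the limit of > 100000 nM in this assay, at which 1 of the 4 values shown sits. Among the compounds shown here, at this aromatic carbon, meta to a large group, carboxy in place of fluoro weakens inhibition sharply, with an at least 13-fold higher number from compound 2 to compound 4 (1.13 log units; beyond the scatter), a drop that the earlier compounds, which hold no exchange at this position, could not reveal. The step has only a lower bound, and the true value of compound 4 stays unresolved.

From the compounds shown here alone, whether a methyl ester, a primary amide or a hydroxy group at this carbon would lose as much remains open. So does whether a carboxylic acid on a longer chain would behave the same way.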